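This account rests on a few compounds, and the source may have more. Where it says the series, first, only, none or still open, it means among the compounds named here.

Measured so far in a functional assay on MDA-MB-231 cells (Homo sapiens) for inhibition, read by MTT assay, with a stated time of 48 h; on this read-out lower numbers stand for stronger inhibition and higher numbers for weaker inhibition:
compound 1 `COc1cc(/C=C/c2ccc(NC(=O)/C=C/c3ccc(F)cc3)cc2)cc(OC)c1` gives 9390 nM
compound 2 `COc1cc(/C=C/c2ccc(NC(=O)/C=C/c3cccc(F)c3)cc2)cc(OC)c1` gives 17300 nM

Compound 2 stands at the higher of the two numbers; its nearest neighbour is compound 1, and the step of a 1.8-fold higher number from compound 1 to compound 2 (0.27 log units; within the scatter) lies within the scatter, so the two values cannot be ordered against each other.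

Compound 3 `COc1cc(/C=C/c2ccc(NC(=O)/C=C/c3ccccc3F)cc2)cc(OC)c1` is not yet measured. It differs from compound 2 in one place: 2-fluorophenyl in place of 3-fluorophenyl on a double-bonded chain carbon bound to a double-bonded chain carbon. For the measured compounds named here, the one measured step that bears on moving the fluorine around the phenyl is a 1.8-fold higher number from compound 1 to compound 2 (0.27 log units; within the scatter), which stayed within the scatter. Going by the values given here, no measured pair covers the 2-fluorophenyl, so nothing in these data speaks for or against it specifically. Among the compounds with values here, the working expectation is therefore no step beyond the scatter in this assay for compound 3, with a wide range kept on both sides because the sole reference step a 1.8-fold higher number from compound 1 to compound 2 (0.27 log units; within the scatter) is itself small and rests on a single pair. Compound 3 is estimated at 15000 nM, between 5000 nM and 45000 nM. This corresponds to an expected step of a 1.2-fold lower number from compound 2 to compound 3 (0.06 log units; within the scatter).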

Compound 3, half-maximal inhibitory concentration: 2380 nM
Estimate against measurement, compound 3: 6.3-fold (0.80 log units) above; the whole stated range lies above it.
By their numbers in this assay, from the lowest: compound 3; then compounds 1 and 2 (each within the scatter of the next).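

In this assay the fluorine's place on the phenyl now makes a difference: 2-fluorophenyl in place of 3-fluorophenyl gives a 7.3-fold lower number from compound 2 to compound 3 (0.86 log units; beyond the scatter) and 2-fluorophenyl in place of 4-fluorophenyl gives a 3.9-fold lower number from compound 1 to compound 3 (0.60 log units; beyond the scatter) on the same double-bonded chain carbon. Both steps lie beyond the scatter, so compound 3 is the most potent of the three, while compound 1 and compound 2 still cannot be ordered against each other; the earlier pair alone gave no sign that a swap between groups with the same atoms could move the number this far at this place. The data at hand offer no explanation for the standing of the 2-fluorophenyl.

Whether this result is specific to fluorine remains open, since the compounds shown include no unsubstituted phenyl, 2-chlorophenyl or 2-methoxyphenyl at this place. Also open, from the compounds shown here alone, is whether the 2-fluorophenyl keeps its advantage when the rest of the core of compound 3 is changed, for example with an amine or a carboxylic acid in place of a methoxy group, and whether the step holds in other cell lines.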